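The source may report more compounds than this note shows. Statements on the series, on what has been measured and on what is new or still open speak of the compounds shown alone.

Within the data shown here, compound 1 `CCCN(CC1CC1)c1nc(C)nc2c(-c3ccc(OC)cc3C)c(C)nn12` is one of three compounds measured in an assay on cell membranes for displacement of a labelled ligand from corticotropin-releasing factor receptor 1 (Rattus norvegicus) (on this read-out higher numbers stand for weaker inhibition and lower numbers for stronger inhibition), where compound 1 gives 1.96 nM. Compound 2 `CCCCN(CC)c1nc(C)nc2c(-c3c(C)cc(OC)cc3OC)c(C)nn12` gives 1.72 nM, a number within the usual scatter of that of compound 1, so the two cannot be told apart. Compound 3 `CCC(CC)Nc1nc(C)nc2c(-c3cc(OC)c(OC)cc3Br)c(C)nn12` gives 6.08 nM, a higher number than that of compound 1 by more than the scatter. Compound 1 therefore sits second highest of the three numbers, nearest to compound 2 and furthest from compound 3.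

Compound 4 `COc1ccc(-c2c(C)nn3c(NC4CCC4)nc(C)nc23)c(C)c1` has not yet been measured. It differs from compound 1 in one place: cyclobutylamino in place of (cyclopropylmethyl)(propyl)amino on an aromatic carbon. Among the measured compounds shown here, no measured pair shows this exact change, so its effect is unknown, and compound 3, the only compound with a clearly higher number, differs from compound 1 in more than one place and is an uncertain guide. In this assay the step from compound 1 to compound 4 is expected to be modest and toward a higher number, a 2.6-fold higher number from compound 1 to compound 4 (0.41 log units; beyond the scatter). Compound 4 is expected to give 5 nM in this assay, with a range from 1.5 nM to 16 nM.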

Compound 4, half-maximal inhibitory concentration: 24.6 nM
Beside the measured number, compound 4's estimate is 4.9-fold (0.69 log units) below it, and the stated range ends below it.
By their numbers in this assay, from the lowest: compounds 2 and 1 (each within the scatter of the next); then compound 3; then compound 4.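

Replacing (cyclopropylmethyl)(propyl)amino with cyclobutylamino on this aromatic carbon, between two ring nitrogen atoms, gives a large change in this assay: a 13-fold higher number from compound 1 to compound 4 (1.10 log units; beyond the scatter). Among these compounds, this shows that the read-out depends strongly on the amino group at this position, which the earlier compounds could not show because they differ from one another in more than one place. Nothing measured here explains the size of this step.

Among the compounds shown here, the single change shortens the group, exchanges a three-membered ring for a four-membered ring and adds a hydrogen-bond donor, so the contribution of each remains open. A (cyclobutyl)(propyl)amino group at this position would keep the four-membered ring and the propyl chain without the donor, and would help to separate these contributions.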